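The compounds below may be only part of what the source reports. "The series", "measured", "known", "first", "only" and "open" are said of these compounds alone.

Measured in an ADME assay on MDCK cells (Canis lupus familiaris) for cytotoxicity, read by MTT assay, with a stated time of 72 h; on this read-out higher numbers stand for lower toxicity in this test and lower numbers for higher toxicity in this test:
Compound 1 `C=C(CC(=O)Nc1ccc(F)cc1F)C(=O)O`: > 110000 nM (a limit)
Compound 2 `C=C(CC(=O)Nc1ccc(F)cc1C(F)(F)F)C(=O)O`: > 110000 nM (a limit)

Compound 2 stands only at a limit of the assay, > 110000 nM, and no number is known for it. Among the compounds with values here, the single measured step, a step that the two limits leave unreadable from compound 1 to compound 2, puts trifluoromethyl in place of fluoro on an aromatic carbon, and it gives no size to build on. Compound 3 `C=C(CC(=O)Nc1ccccc1C(F)(F)F)C(=O)O` follows by hydrogen in place of fluoro on an aromatic carbon, with hydrogen in place of fluoro on an aromatic carbon. Within the data shown here, the only guide is that compound 1 and compound 2 both sit at the limit of > 110000 nM in this assay, at which 2 of the 2 values shown sit. No step beyond the usual scatter is therefore expected in this assay, in either direction, and another limit is likely. The expected step is a step that the limit leaves unreadable from compound 2 to compound 3. Compound 3 is estimated at 120000 nM, with an expected range from 70000 nM to 300000 nM.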

Compound 3, half-maximal cytotoxic concentration: > 110000 nM
Compound 3 ended at the assay's limit (the forecaster's own chance of this, stated with the estimate: 85%); the middle value is on the limit's open side.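

No step can be read between compound 2 and compound 3 in this assay and all three compounds stand alike: the limit of > 110000 nM in this assay, at which 3 of the 3 values shown sit. The compounds shown leave open at what concentration any of them would reach half-maximal cytotoxicity, and whether either exchange changes that concentration at all.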